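Replacing the nitrophenyl on the ring nitrogen with a fluorobenzoyl

A few compounds are considered here, and "the series" means these few. Any claim that something is new, unique, unknown or untested is made for them only; others in the source may bear on it.

Measured compounds:
compound 1 `O=C1NN(c2ccccc2)C(=O)/C1=C/c1cccc(OCc2cccc(F)c2)c1`: 4790 nM
compound 2 `O=C1NN(c2ccccc2)C(=O)/C1=C/c1cccc(OCc2cccc(C(F)(F)F)c2)c1`: 6920 nM
compound 3 `Cc1cccc(COc2cccc(/C=C3\C(=O)NN(c4ccccc4[N+](=O)[O-])C3=O)c2)c1`: 5370 nM

All three compounds share one core and were tested in a functional assay on cells for agonist activity at Bile acid receptor (Homo sapiens), read by a luciferase reporter; on this read-out higher numbers stand for an effect only at larger amounts of compound and lower numbers for an effect already at smaller amounts. In this assay, among the compounds with values here, compound 1 gives 4790 nM, and compound 2 gives 6920 nM; the one step that links them, a 1.4-fold higher number from compound 1 to compound 2 (0.16 log units; within the scatter), lies within the scatter. Compound 3 gives 5370 nM in this assay, a value that sits in the same span as those of compound 1 and compound 2, with the gaps to both within the scatter.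

Compound 4 `Cc1cccc(COc2cccc(/C=C3\C(=O)NN(C(=O)c4ccc(F)cc4)C3=O)c2)c1` has not yet been measured. It differs from compound 3 in one place: (4-fluorophenyl)carbonyl in place of 2-nitrophenyl on an amide-type nitrogen in a ring. Within the data shown here, none of the measured steps touches this position; the only step on record, from compound 1 to compound 2, changes a substituent on the benzyl ether instead, and it stayed within the scatter. There is thus no measured guide for the new change, and the expectation rests only on the narrow span of the three values shown.

The estimated step of a 1.1-fold higher number from compound 3 to compound 4 (0.05 log units; within the scatter) is therefore expected to be no larger than the scatter, with wide uncertainty in either direction. Compound 4 is expected to give about 6000 nM in this assay, in a range from 2500 nM to 15000 nM.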

Compound 4, half-maximal effective concentration: 1860 nM
Compound 4: middle estimate off by 3.2-fold (0.51 log units), on the high side; the measured number lies below the stated range.
By their numbers in this assay, from the lowest: compound 4; then compounds 1, 3 and 2 (each within the scatter of the next).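

Within the data shown here, the nitrogen position turns out to be responsive in this assay: a 2.9-fold lower number from compound 3 to compound 4 (0.46 log units; beyond the scatter), and this is the first step in the set to pass beyond the scatter, whereas the only earlier step, a 1.4-fold higher number from compound 1 to compound 2 (0.16 log units; within the scatter), changed a substituent on the benzyl ether and stayed within it. The change keeps a six-membered aromatic ring of carbon in the group on the ring nitrogen, but it replaces 2-nitrophenyl with (4-fluorophenyl)carbonyl, so a carbonyl now stands on that nitrogen and the nitro group is gone, and the lower number means that compound 4 shows its effect at smaller amounts than compound 3. Nothing available bears on why this exchange moves the number.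

The compounds shown leave open which part of the new group carries the step, since a plain benzoyl, a 4-fluorophenyl without the carbonyl or a small acetyl on the same nitrogen would each separate the carbonyl, the fluorine and the ring. They also leave open whether the same exchange would act alike with the fluoro or trifluoromethyl benzyl ethers of compound 1 and compound 2.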